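Triazolylmethyl spiro series: aryl swap at the triazole nitrogen

The source may hold more compounds than are shown below. What is called first, only, known or untested is meant among the compounds shown, and "the series" means these compounds.

Measured so far:
- compound 1 `CCc1ccccc1-n1nncc1CN1C(=O)C2(C(C#N)=C(N)Oc3c(N)cc4nc5ccccc5nc4c32)c2ccccc21`; in an ADME assay on HUVEC cells (Homo sapiens) for antiproliferative activity, read by MTT assay, with a stated time of 48 h (a lower number here means a stronger inhibitor, a higher number a weaker inhibitor), compound 1 gives > 50000 nM, which is a limit of the assay and not a number.
- compound 2 `CCc1cccc(CC)c1-n1nncc1CN1C(=O)C2(C(C#N)=C(N)Oc3c(N)cc4nc5ccccc5nc4c32)c2ccccc21`; in this assay compound 2 gives > 50000 nM, likewise a limit of the assay.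

Compound 2 thus stands at the limit, with no number of its own; every value shown so far sits there (the limit of > 50000 nM in this assay, at which 2 of the 2 values shown sit). The step that the two limits leave unreadable from compound 1 to compound 2 cannot be read, as both of its ends are limits. Compound 3 `N#CC1=C(N)Oc2c(N)cc3nc4ccccc4nc3c2C12C(=O)N(Cc1cnnn1-c1ccc(Cl)cc1Cl)c1ccccc12` differs from compound 2 by 2,4-dichlorophenyl in place of 2,6-diethylphenyl on an aromatic nitrogen. For the measured compounds named here, no measured step with a readable size bears on this change, and nothing in the values shown points in either direction beyond the scatter. Going by the values given here, compound 3 is therefore expected to remain at or near the limit, with an expected step that the limit leaves unreadable from compound 2 to compound 3 that no measured step can be set against. The estimate for compound 3 is 60000 nM, within 20000 nM to 200000 nM, and most likely reported again only as a limit.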

Compound 3, half-maximal inhibitory concentration: > 50000 nM
Compound 3: only a limit was reported; the forecaster's own chance of this, stated with the estimate: 80%; the middle value does not contradict the limit.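

No step among compound 1, compound 2 and compound 3 can be read, as each value is a limit of the assay and not a number: the limit of > 50000 nM in this assay, at which 3 of the 3 values shown sit.

The compounds shown leave open whether any aryl group on this aromatic nitrogen gives a readable value in this assay.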